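The source may hold more compounds than are shown below. What is called first, only, known or untested is meant among the compounds shown, and "the series" means these compounds.

Working notes on the series. Compound 1 `COc1ccc2c(c1)NC(=O)CN2c1nc(NCCCO)nc2ccccc12` gives 7.43 nM in a functional assay on MCF7 cells (Homo sapiens) for inhibition, read by sulforhodamine B assay, with a stated time of 48 h (a lower number here means a stronger inhibitor of growth, a higher number a weaker inhibitor of growth), and has the lowest number of the two measured; compound 2 `COc1ccc2c(c1)NC(=O)CN2c1nc(Nc2cccc(C#N)c2)nc2ccccc12` gives 384 nM, the step of a 52-fold higher number from compound 1 to compound 2 (1.71 log units; beyond the scatter). Compound 3 `COc1ccc2c(c1)NC(=O)CN2c1nc(COC(C)=O)nc2ccccc12` carries the change (acetoxymethyl in place of (3-hydroxypropyl)amino on an aromatic carbon). Going by the values given here, only that one step bears on it, and only partly, since the change in compound 3 removes the (3-hydroxypropyl)amino group entirely rather than exchanging its 3-hydroxypropyl part. A loss of potency is nonetheless expected, of a size near a 20-fold higher number from compound 1 to compound 3 (1.31 log units; beyond the scatter), with wide uncertainty. Compound 3 is estimated at 150 nM, with a range of 20 nM to 1500 nM.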

Compound 3, concentration for 50% growth inhibition in the MCF7 assay: 33 nM
Estimate against measurement, compound 3: 4.5-fold (0.66 log units) above; low and high end bracket the measured number.
By their numbers in the MCF7 assay, from the lowest: compound 1; then compound 3; then compound 2.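

At this aromatic carbon between two ring nitrogen atoms, the amino link and both hydrogen-bond donors of compound 1 can be lost with only part of the activity going in the MCF7 assay: a 4.4-fold higher number from compound 1 to compound 3 (0.65 log units; beyond the scatter), while a 12-fold lower number from compound 2 to compound 3 (1.07 log units; beyond the scatter). The change also separates the two read-outs: in a physicochemical assay for solubility, read by HPLC, at pH 7.4 (on this read-out higher numbers stand for higher solubility and lower numbers for lower solubility), compound 1 gives 80.9 ug/mL and compound 3 gives 8.07 ug/mL.

Open, on these data alone, is whether a hydroxymethyl group or a longer ester chain at this position would bring the MCF7 assay number closer to that of compound 1 while giving a higher the physicochemical assay number than compound 3.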